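A sulfonyl aryl exchange within a shared core

The source may report more compounds than this note shows. Statements on the series, on what has been measured and on what is new or still open speak of the compounds shown alone.

Compound 1, `Cc1ccc(-c2ccc(C3(C)CC(S(=O)(=O)c4ccc(F)cc4)=C(c4ccc(/C(N)=N\O)cc4)O3)cc2)cc1`: 13700 nM
Compound 2, `CC1(Cc2ccccc2)CC(S(=O)(=O)c2ccccc2F)=C(c2ccc(/C(N)=N\O)cc2)O1`: 61700 nM
Compound 3, `CC1(c2ccc(Br)cc2)CC(S(=O)(=O)c2ccc(F)cc2)=C(c2ccc(/C(N)=N\O)cc2)O1`: 19200 nM

Of the compounds shown here, three share a core and have been tested in an ADME assay on HepG2 cells (Homo sapiens) for cytotoxicity, read by MTT assay, with a stated time of 72 h; a lower number here means that less compound is tolerated, a higher number that more compound is tolerated. Compound 1 gives 13700 nM and compound 3 gives 19200 nM; the step of a 1.4-fold higher number from compound 1 to compound 3 (0.15 log units; within the scatter) stays within the scatter. Compound 2 stands highest of the three numbers in this assay with 61700 nM, its nearest neighbour being compound 3 and its furthest compound 1, both gaps beyond the scatter.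

Compound 4, `CC1(Cc2ccccc2)CC(S(=O)(=O)c2cccc(C(F)(F)F)c2)=C(c2ccc(/C(N)=N\O)cc2)O1`, is not yet measured. It differs from compound 2 by 3-(trifluoromethyl)phenyl in place of 2-fluorophenyl on a sulfonyl sulfur. Going by the values given here, the only step measured so far changes the group on the aromatic carbon of the core, not the ring on the sulfonyl sulfur, so no measured step bears directly on this exchange. With nothing to point either way, the number for compound 4 is expected to stay close to that of compound 2, with a step of a 1.2-fold lower number from compound 2 to compound 4 (0.09 log units; within the scatter) that should not pass beyond the scatter. Compound 4 is therefore estimated at 50000 nM in this assay, within a range from 18000 nM to 140000 nM.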

Compound 4, half-maximal cytotoxic concentration: 33400 nM
Compound 4: the middle estimate sits 1.5-fold (0.18 log units) above what was measured, and the stated range covers the measured number.
By their numbers in this assay, from the lowest: compounds 1, 3, 4 and 2 (each within the scatter of the next, the first and the last beyond it).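

In this assay, going by these compounds alone, placing 3-(trifluoromethyl)phenyl instead of 2-fluorophenyl on the sulfonyl sulfur gives a 1.8-fold lower number from compound 2 to compound 4 (0.27 log units; within the scatter) and provides the first measured step at this position. For this one pair, then, a larger aryl group with three fluorines in place of one leaves the number within the scatter, whereas the earlier step concerned only the group on an aromatic carbon. No measured property is available to account for this result.

Compound 1 and compound 3 carry a different sulfonyl ring but also differ from compound 2 and compound 4 elsewhere, so their ring cannot be placed alongside this step. Going by these compounds, it remains open whether an aryl ring bearing an amine or a carboxylic acid, or a simple methyl group, on the sulfonyl sulfur would also stay within the scatter.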